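The source may hold more compounds than are shown below. What is called first, only, known or untested is meant among the compounds shown, and "the series" means these compounds.

Of the compounds shown here, three sharing one core have been tested in an ADME assay on MT4 cells (Homo sapiens) for cytotoxicity, read by MTT assay, with a stated time of 4 days; on this read-out lower numbers stand for higher toxicity in this test and higher numbers for lower toxicity in this test. Compound 1 `COc1ccccc1Oc1nc(Nc2ccc(C#N)cc2)nc2ccccc12` carries a 2-methoxyphenyl group on an oxygen on an aromatic ring, and in this assay compound 1 gives 150000 nM. Compound 2 `N#Cc1ccc(Nc2nc(Oc3ccc(Cl)cc3Cl)c3ccccc3n2)cc1` gives 32000 nM, and compound 3 `Cc1cc(Br)c(Oc2nc(Nc3ccc(C#N)cc3)nc3ccccc23)c(Br)c1` gives 25000 nM. Compound 3 thus shows the lowest number of the three, though its gap to compound 2 is within the scatter, so the two cannot be ranked; only its gap to compound 1 is clear.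

Compound 4 `N#Cc1ccc(Nc2nc(Oc3ccc(Cl)cc3)c3ccccc3n2)cc1` has not yet been measured. It differs from compound 3 in one place: 4-chlorophenyl in place of 2,6-dibromo-4-methylphenyl on an oxygen on an aromatic ring. For the measured compounds named here, no measured step makes exactly this change. The nearest guides are a 4.7-fold lower number from compound 1 to compound 2 (0.67 log units; beyond the scatter) and a 6.0-fold lower number from compound 1 to compound 3 (0.78 log units; beyond the scatter), both replacing 2-methoxyphenyl with a halogen-bearing phenyl, while a 1.3-fold lower number from compound 2 to compound 3 (0.11 log units; within the scatter) shows that swapping one halogenated phenyl for another changed little. Since compound 4 keeps one halogen but loses two, a modest rise in the number is expected, giving a 2.2-fold higher number from compound 3 to compound 4 (0.34 log units; beyond the scatter). Compound 4 is estimated at 55000 nM, within a range of 25000 nM to 130000 nM.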

Compound 4, half-maximal cytotoxic concentration: 198000 nM
Compound 4: middle estimate off by 3.6-fold (0.56 log units), on the low side; the whole stated range lies below it.
By their numbers in this assay, from the lowest: compounds 3 and 2 (each within the scatter of the next); then compounds 1 and 4 (each within the scatter of the next).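

Removing one chloro, so that 4-chlorophenyl replaces 2,4-dichlorophenyl, gives a 6.2-fold higher number from compound 2 to compound 4 (0.79 log units; beyond the scatter) and shows that a single halogen atom on this ring can shift the number clearly, although the earlier swap between two halogen-bearing groups did not. Replacing 2,6-dibromo-4-methylphenyl with 4-chlorophenyl gives a 7.9-fold higher number from compound 3 to compound 4 (0.90 log units; beyond the scatter) and shows that a halogen on this group does not by itself bring a low number, as compound 4 still carries chlorine. Replacing 2-methoxyphenyl with 4-chlorophenyl gives a 1.3-fold higher number from compound 1 to compound 4 (0.12 log units; within the scatter) and leaves these two groups indistinguishable in this test.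

Still open, from the compounds shown here alone, is how a plain phenyl group with no halogen, or a phenyl carrying an amine or a carboxylic acid, would behave on this oxygen. Nothing available here accounts for any of these steps.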